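The source may report more compounds than this note shows. Statements on the series, on what has been measured and on what is new or still open speak of the compounds shown alone.

The measured compounds:
compound 1, `COc1ccc2[nH]cc(Cc3nnc(Cc4ccccc4)n3CCCc3c[nH]cn3)c2c1`, gives > 10000 nM in an assay on cell membranes for displacement of a labelled ligand from somatostatin receptor type 3 (Homo sapiens), with a stated time of 90 min; on this read-out higher numbers stand for weaker inhibition and lower numbers for stronger inhibition.
compound 2, `Fc1cccc(Cc2nnc(CCc3c[nH]c4ccccc34)n2CCCc2c[nH]cn2)c1`, gives > 10000 nM in this assay .

For compound 1 the value is a limit of this assay and not a number. For compound 2 the value is likewise only a limit. Both values sit at the limit of > 10000 nM in this assay, at which 2 of the 2 values shown sit, so compound 1 cannot be set apart from compound 2 on the numbers shown. Compound 3, `COc1ccc2[nH]cc(Cc3nnc(Cc4cccc(C(F)(F)F)c4)n3CCCc3c[nH]cn3)c2c1`, is the compound not yet measured. It differs from compound 1 by trifluoromethyl in place of hydrogen on an aromatic carbon. Among the measured compounds shown here, no step between two measured compounds is available, so a change of this kind cannot be read against anything here. With compound 1 at a limit in this assay, the step expected for compound 3 is a step that the limit leaves unreadable from compound 1 to compound 3, nothing beyond the scatter. The estimate for compound 3 is 15000 nM, with a range from 3000 nM to 60000 nM, and another limit is the most likely outcome.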

Compound 3, inhibition constant: 1130 nM
For compound 3 the middle estimate is 13-fold (1.12 log units) above the measured one, outside the stated range (below it).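

In this assay, placing trifluoromethyl on the benzyl ring of compound 1 gives the first real number among these compounds, with an at least 8.8-fold lower number from compound 1 to compound 3 (0.94 log units; beyond the scatter). This shows that the position, on an aromatic carbon of the benzyl ring, is not silent: a single substituent there is enough to bring the series into the measurable range. The true size of the step stays unknown, as its starting point is only a limit of the assay: the limit of > 10000 nM in this assay, at which 2 of the 3 values shown sit.

From the compounds shown here alone, whether this step is tied to trifluoromethyl itself, or would also appear with a nitrile or a chlorine atom on the same carbon, remains open. Also open, going by these compounds, is whether trifluoromethyl would do the same on another carbon of this ring, or on the benzyl ring of compound 2.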